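Ethyl to 3-fluorophenyl on the Aryloxy Chain

The compounds below may be only part of what the source reports. "The series", "measured", "known", "first", "only" and "open" are said of these compounds alone.

Compound 1 `O=C1CC(c2ccccc2OCc2ccc(F)cc2)Oc2ccccc21`: 25500 nM in a functional assay on J774.A1 cells (Mus musculus) for inhibition, read by Griess assay, with stated times of 1 h and 24 h; on this read-out lower numbers stand for stronger inhibition and higher numbers for weaker inhibition
Compound 2 `CCCOc1ccccc1C1CC(=O)c2ccccc2O1`: 44600 nM
Compound 3 `COc1ccccc1C1CC(=O)c2ccccc2O1`: 44500 nM

Compound 2 gives the highest of the three numbers in this assay, yet its gap to compound 3 is nil and the remaining gap is only a 1.7-fold higher number from compound 1 to compound 2 (0.24 log units; within the scatter), so all three sit within the scatter. Compound 4 `O=C1CC(c2ccccc2OCc2cccc(F)c2)Oc2ccccc21` is not yet measured; the change from compound 2 is 3-fluorophenyl in place of ethyl on a saturated chain carbon bound to an oxygen on an aromatic ring. Among the measured compounds shown here, the nearest precedent is the step of a 1.7-fold higher number from compound 1 to compound 2 (0.24 log units; within the scatter), a change of the same kind with 4-fluorophenyl, and also a 1.0-fold lower number from compound 2 to compound 3 (0.00 log units; within the scatter); neither moves the number beyond the scatter. A step of about a 1.6-fold lower number from compound 2 to compound 4 (0.20 log units; within the scatter) is therefore expected, toward compound 1. Compound 4 is estimated at 28000 nM, with a range of 14000 nM to 56000 nM.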

Compound 4, half-maximal inhibitory concentration: 13200 nM
The estimate for compound 4 lay 2.1-fold (0.33 log units) above the measured number; measured number below the stated range.
By their numbers in this assay, from the lowest: compounds 4, 1, 3 and 2 (each within the scatter of the next, the first and the last beyond it).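

In this assay, among the compounds shown here, the steps of a 3.4-fold lower number from compound 2 to compound 4 (0.53 log units; beyond the scatter) and a 3.4-fold lower number from compound 3 to compound 4 (0.53 log units; beyond the scatter) are the first at this saturated chain carbon to lie beyond the scatter, whereas 4-fluorophenyl in compound 1 stayed within it against ethyl and hydrogen. Yet the two fluorophenyl groups cannot be told apart, since a 1.9-fold lower number from compound 1 to compound 4 (0.29 log units; within the scatter) remains within the scatter. Nothing measured here explains the modest gain. Still open, from the compounds shown here alone, is whether the gain needs the fluorine at all, and how a plain benzyl, a 3-chlorobenzyl or a longer chain such as butyl would read at this position.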